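This account rests on a few compounds, and the source may have more. Where it says the series, first, only, none or still open, it means among the compounds named here.

Compound 1 `O=C(CSc1nc(Nc2ccccc2)c2ccccc2n1)Nc1ccccc1Cl`: 24400 nM
Compound 2 `C=CC(=O)Nc1cccc(NC(=O)CSc2nc(Nc3ccccc3)c3ccccc3n2)c1`: 10200 nM

In a functional assay on MDA-MB-231 cells (Homo sapiens) for inhibition, read by MTT assay, with a stated time of 72 h (on this read-out higher numbers stand for weaker inhibition and lower numbers for stronger inhibition), compound 1 gives 24400 nM, and compound 2 gives 10200 nM, the lowest of the two numbers. Among the measured compounds shown here, the one measured step, a 2.4-fold lower number from compound 1 to compound 2 (0.38 log units; beyond the scatter), came with a change of the group on the amide-type nitrogen. Compound 3 `CCc1ccc(NC(=O)CSc2nc(Nc3ccccc3)c3ccccc3n2)cc1` carries the change (4-ethylphenyl in place of 3-((vinylcarbonyl)amino)phenyl on an amide-type nitrogen), on an amide-type nitrogen whose other neighbour is a carbonyl carbon. For the measured compounds named here, the entering group, like the group in compound 1, brings no hydrogen-bond donor or acceptor, so the step from compound 1 to compound 2 is the only guide, and it points to compound 3 landing back near compound 1. Compound 3 is therefore expected to give 20000 nM in this assay, within 8000 nM to 50000 nM. That expectation means a step of a 2.0-fold higher number from compound 2 to compound 3 (0.29 log units; within the scatter), a modest rise in the number beyond the scatter.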

Compound 3, half-maximal inhibitory concentration: 33900 nM
Estimate against measurement, compound 3: 1.7-fold (0.23 log units) below, and the stated range covers the measured number.
By their numbers in this assay, from the lowest: compound 2; then compounds 1 and 3 (each within the scatter of the next).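

In this assay, replacing the 3-((vinylcarbonyl)amino)phenyl group on the amide-type nitrogen with 4-ethylphenyl gives a 3.3-fold higher number from compound 2 to compound 3 (0.52 log units; beyond the scatter), so compound 2 now stands apart from two different partners at this position, not only from the 2-chlorophenyl compound. The other exchange, a 1.4-fold higher number from compound 1 to compound 3 (0.14 log units; within the scatter), shows that 2-chlorophenyl and 4-ethylphenyl cannot be told apart here, so the two groups without hydrogen-bond donors or acceptors give matching results in this pair. No available evidence explains why the 3-((vinylcarbonyl)amino)phenyl group gives the lower number.

On these data alone, it remains open whether that lower number depends on the vinylcarbonyl part or on the amide nitrogen that carries it. A propanoyl amide or a plain amine on the phenyl ring would separate these two possibilities.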